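Swapping a Methyl for a Chlorophenyl on the Ring Nitrogen

The compounds below may be only part of what the source reports. "The series", "measured", "known", "first", "only" and "open" are said of these compounds alone.

Of the compounds shown here, three built on a shared core have been tested in a functional assay on CCRF-CEM cells (Homo sapiens) for cytotoxicity, read by cell counting, with a stated time of 3 days; a lower number here means a stronger inhibitor, a higher number a weaker inhibitor. Compound 1 `C=C(Br)C(=O)Nc1ccc(/C=C2\SC(=O)N(CC)C2=O)cc1` gives 870 nM. Compound 2 `CCN1C(=O)S/C(=C\c2ccc(N)cc2)C1=O` gives 91000 nM, and the step of a 100-fold higher number from compound 1 to compound 2 (2.02 log units; beyond the scatter) separates the two. Compound 3 `CC(C)(C)c1ccc(CN2C(=O)S/C(=C\c3ccc(N)cc3)C2=O)cc1` gives 66000 nM; set against compound 2, that value falls within the usual scatter, so the two cannot be ranked against each other. Among the three, compound 2 therefore stands far from compound 1 and close to compound 3.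

The new compound 4 `Nc1ccc(/C=C2\SC(=O)N(Cc3cccc(Cl)c3)C2=O)cc1` differs from compound 2 only in this: 3-chlorophenyl in place of methyl on a saturated chain carbon bound to an amide-type nitrogen in a ring. Going by the values given here, no measured step changes the group at that place, so nothing bears on it directly. The only step shown, a 100-fold higher number from compound 1 to compound 2 (2.02 log units; beyond the scatter), alters a different part of the molecule and says nothing about what happens here. The nearest guide is the pair of compound 2 and compound 3, whose values sit within the scatter of each other while carrying different groups on that same chain carbon.

On that basis the expected change is a 1.2-fold lower number from compound 2 to compound 4 (0.08 log units; within the scatter), none beyond the scatter. Compound 4 is estimated at 75000 nM in this assay, with a range from 25000 nM to 220000 nM.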

Compound 4, half-maximal inhibitory concentration: 18000 nM
Estimate against measurement, compound 4: 4.2-fold (0.62 log units) above; measured number outside the range, below it.
By their numbers in this assay, from the lowest: compound 1; then compound 4; then compounds 3 and 2 (each within the scatter of the next).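

Putting 3-chlorophenyl in place of methyl on a saturated chain carbon bound to an amide-type nitrogen in a ring gives a 5.1-fold lower number from compound 2 to compound 4 (0.70 log units; beyond the scatter) in this assay, so this position does respond to the group it carries, something the values of compound 2 and compound 3, within the scatter of each other, had given no sign of. An aromatic ring at this place does not settle the outcome by itself: compound 3 also carries one there and gives 66000 nM, while compound 4 gives 18000 nM, so what matters is which ring sits there. No measurement at hand offers a reason for this shift.

The compounds shown leave open how much of the change belongs to the chlorine and how much to the ring itself, a question that a plain phenyl group on the same carbon would address. Also open, as far as these compounds go, is whether 3-chlorophenyl would move the number in the same direction in a compound that keeps the (1-bromoethenyl)carbonyl group of compound 1.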